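The source may hold more compounds than are shown below. What is called first, only, known or untested is meant among the compounds shown, and "the series" means these compounds.

Measured so far:
Compound 1 `CCN(CC)C(=O)c1cc2sccc2n1Cc1ccc(OC)cc1` — in an ADME assay on HEK-293T cells (Homo sapiens) for cytotoxicity, read by luminescence, with a stated time of 24 h (a higher number here means that more compound is tolerated, a lower number that less compound is tolerated), compound 1 gives > 100000 nM, a limit of the assay.
Compound 2 `COc1ccc(Cn2c(C(=O)N3CCCC3)cc3sccc32)cc1` — compound 2 gives > 100000 nM, also a limit.
Compound 3 `CCOC(=O)C1CCN(C(=O)c2cc3sccc3n2Cc2ccc(OC)cc2)CC1` — compound 3 gives 39000 nM.

Going by the values given here, compound 3 thus holds the only number in this assay; the other two values are limits, as noted by the limit of > 100000 nM in this assay, at which 2 of the 3 values shown sit. Among the compounds with values here, the one step between measured compounds, a step that the two limits leave unreadable from compound 1 to compound 2, cannot be read against two limits.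

Compound 4 `COc1ccc(Cn2c(C(=O)N3CCC(C(=O)NCC4CC4)CC3)cc3sccc32)cc1` differs from compound 3 by (cyclopropylmethyl)amino in place of ethoxy on a carbonyl carbon. Within the data shown here, no measured step touches this position, so there is no basis for expecting a shift beyond the scatter. Compound 4 is therefore estimated near compound 3, at 50000 nM within 20000 nM to 150000 nM. The expected step of a 1.3-fold higher number from compound 3 to compound 4 (0.11 log units; within the scatter) is read as lying within the scatter.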

Compound 4, half-maximal cytotoxic concentration: 24600 nM
Compound 4: the middle estimate sits 2.0-fold (0.31 log units) above what was measured, within the range that was stated.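

In this assay, the change from ethoxycarbonyl to (cyclopropylmethyl)carbamoyl gives a 1.6-fold lower number from compound 3 to compound 4 (0.20 log units; within the scatter). Going by these compounds alone, this is the only readable step so far, and it shows that this carbonyl carbon accepts the amide hydrogen and a three-membered ring with no shift beyond the scatter. Compound 4, like compound 3, gives a number and not a limit: the limit of > 100000 nM in this assay, at which 2 of the 4 values shown sit.

From the compounds shown here alone, whether a carboxylic acid at this carbonyl carbon would read the same remains open. So does the effect of a longer chain in place of (cyclopropylmethyl)amino.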